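Carbonyl group exchange from compound 3 to compound 4

The source may hold more compounds than are shown below. What is called first, only, known or untested is meant among the compounds shown, and "the series" means these compounds.

Compound 1 `CCn1c(C(=O)NCCN(C)C)ccc1C(CC)(CC)c1ccc(OCCC(O)(CC)CC)c(C)c1`: 870 nM
Compound 2 `CCn1c(C(=O)N(CCC#N)CCC#N)ccc1C(CC)(CC)c1ccc(OCCC(O)(CC)CC)c(C)c1`: > 50000 nM, a limit
Compound 3 `C#CCCOC(=O)c1ccc(C(CC)(CC)c2ccc(OCCC(O)(CC)CC)c(C)c2)n1CC`: > 50000 nM, a limit

In a functional assay on PC-3 cells (Homo sapiens) for antiproliferative activity, read by MTT assay, with a stated time of 48 h (on this read-out lower numbers stand for stronger inhibition and higher numbers for weaker inhibition), compound 3 gives only a limit, > 50000 nM. Compound 4 `CCOC(=O)C(CC(=O)OC)NC(=O)c1ccc(C(CC)(CC)c2ccc(OCCC(O)(CC)CC)c(C)c2)n1CC` brings this change: a group of 12 heavy atoms (7 carbon, 1 nitrogen, 4 oxygen; no ring) in place of a group of 5 heavy atoms (4 carbon, 1 oxygen; no ring), on a carbonyl carbon. For the measured compounds named here, two measured steps bear on it: an at least 57-fold higher number from compound 1 to compound 2 (1.75 log units; beyond the scatter) and an at least 57-fold higher number from compound 1 to compound 3 (1.75 log units; beyond the scatter), both large. Going by the values given here, compound 4 lacks the (2-(dimethylamino)ethyl)amino of compound 1, the only compound with a number so far. A value at or close to the limit is therefore expected, with only a modest chance of a lower number. The expected step is an at least 1.6-fold lower number from compound 3 to compound 4 (0.22 log units; that floor lies within the scatter). For compound 4 the estimated value is 30000 nM, with an expected range of 8000 nM to 50000 nM.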

Compound 4, half-maximal inhibitory concentration: 5840 nM
Compound 4: the middle estimate sits 5.1-fold (0.71 log units) above what was measured; measured number below the stated range.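

In this assay, a group on this carbonyl carbon without the (2-(dimethylamino)ethyl)amino of compound 1 can still give a number, with an at least 8.5-fold lower number from compound 3 to compound 4 (0.93 log units; beyond the scatter) and an at least 8.5-fold lower number from compound 2 to compound 4 (0.93 log units; beyond the scatter). That group does not match compound 1, however: a 6.7-fold higher number from compound 1 to compound 4 (0.83 log units; beyond the scatter). The first two steps are floors, set by limits rather than numbers: the limit of > 50000 nM in this assay, at which 2 of the 4 values shown sit.

The compounds shown do not separate the contribution of the amide hydrogen from that of the two ester groups in compound 4. On these data alone, how a carboxylic acid in place of those esters, or a longer chain ending in an amine, would read also remains open.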